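The compounds below may be only part of what the source reports. "The series", "measured", "known", "first", "only" and "open" are said of these compounds alone.

Compound 1 `COc1cc(C(=O)/C=C/c2ccc(OCCCC(=O)NCCCNCCCCN)cc2)cc(OC)c1OC` sits at the upper limit in a functional assay on DU-145 cells (Homo sapiens) for antiproliferative activity, read by MTT assay, with a stated time of 48 h (a higher number here means a weaker inhibitor, a lower number a stronger inhibitor), where compound 1 gives > 100000 nM, a limit rather than a number. Compound 4 `COc1cc(C(=O)/C=C/c2ccc(OCCCC(=O)NCCCNCCCCNCCN)cc2)cc(OC)c1OC` carries 2-aminoethyl in place of hydrogen on an amine nitrogen. Going by the values given here, the only measured step from compound 1 is an at least 1.8-fold lower number from compound 1 to compound 3 (0.26 log units; that floor lies within the scatter), reaching compound 3 `COc1cc(C(=O)/C=C/c2ccc(OCCCC(=O)NCCCCNCCCN)cc2)cc(OC)c1OC`, which in this assay gives 54800 nM. Among the compounds with values here, compound 2 `COc1ccc(/C=C/C(=O)c2cc(OC)c(OC)c(OC)c2)cc1OCCCC(=O)NCCCNCCCCNCCN`, whose polyamine chain ends in the same 2-aminoethyl group that enters here, gives 28500 nM in this assay, though its core substitution differs from that of compound 4 and no single step links them. Since compound 1 is only a limit, compound 4 is expected to move an at least 2.2-fold lower number from compound 1 to compound 4 (0.34 log units; beyond the scatter), and its value is estimated at 45000 nM, within 15000 nM to 150000 nM.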

Compound 4, half-maximal inhibitory concentration in the DU-145 assay: 35400 nM
Beside the measured number, compound 4's estimate is 1.3-fold (0.10 log units) above it; low and high end bracket the measured number.
By their numbers in the DU-145 assay, from the lowest: compounds 2, 4 and 3 (each within the scatter of the next). At a limit, above all of these: compound 1.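

Going by these compounds alone, in the DU-145 assay, 2-aminoethyl in place of hydrogen on an amine nitrogen gives the first step beyond the scatter at this position, an at least 2.8-fold lower number from compound 1 to compound 4 (0.45 log units; beyond the scatter), while the comparison with the rearranged chain gives a 1.5-fold lower number from compound 3 to compound 4 (0.19 log units; within the scatter). In the DU-145 assay compound 1 stands at a limit, > 100000 nM, not at a number. In a physicochemical assay for lipophilicity, read by spectrophotometry, measured as octanol-water partition, tested at 300 uM (on this read-out lower numbers stand for lower lipophilicity and higher numbers for higher lipophilicity), compound 1 gives -1.43 and compound 4 gives -1.98, which is a number 0.55 log units lower from compound 1 to compound 4 (beyond the scatter).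

The compounds shown leave open how large the step truly is, since its starting point is only a limit. They also leave open whether a 3-aminopropyl or an acetyl group on this nitrogen would give a similar step.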